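This account rests on a few compounds, and the source may have more. Where it says the series, first, only, none or still open, it means among the compounds named here.

Measured compounds:
Compound 1, `CN1CCN(Cc2nnc(-c3cc(S(N)(=O)=O)c(SCc4ccccc4)cc3Cl)o2)CC1`, 75000 nM in a functional assay on MCF7 cells (Homo sapiens) for cytotoxicity, read by MTT assay, with a stated time of 72 h; a lower number here means a stronger inhibitor, a higher number a weaker inhibitor.
Compound 2, `NS(=O)(=O)c1cc(-c2nnc(Cn3cc(-c4ccccc4)nn3)o2)c(Cl)cc1SCc1ccccc1`, 170000 nM in this assay.
Compound 3, `NS(=O)(=O)c1cc(-c2nnc(/C=C/c3ccccc3)o2)c(Cl)cc1SCc1ccccc1`, 16000 nM in this assay.

Compound 3 holds the lowest number of the three. Its nearest neighbour is compound 1, with a step of a 4.7-fold lower number from compound 1 to compound 3 (0.67 log units; beyond the scatter); compound 2 lies furthest away, with a step of an 11-fold lower number from compound 2 to compound 3 (1.03 log units; beyond the scatter). Compound 1 and compound 2 in turn differ by a 2.3-fold higher number from compound 1 to compound 2 (0.36 log units; beyond the scatter).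

Compound 4, `NS(=O)(=O)c1cc(-c2nnc(/C=C/c3ccc(Cl)cc3)o2)c(Cl)cc1SCc1ccccc1`, has not yet been measured in this assay. It differs from compound 3 by chloro in place of hydrogen on an aromatic carbon. For the measured compounds named here, none of the measured steps touches this kind of change: each of them replaces the whole substituent on the shared core, whereas here the 2-phenylethenyl group is kept and only a hydrogen on its six-membered aromatic ring gives way to chloro. The measured steps therefore give no direct guide, and the change is a small one in heavy atoms.

For compound 4 the number in this assay is expected to be close to that of compound 3, a step of a 1.3-fold lower number from compound 3 to compound 4 (0.12 log units; within the scatter), which is estimated to stay within the usual scatter. The estimate for compound 4 is 12000 nM, with a range from 4000 nM to 40000 nM.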

Compound 4, half-maximal inhibitory concentration: 11000 nM
Beside the measured number, compound 4's estimate is 1.1-fold (0.04 log units) above it; low and high end bracket the measured number.
By their numbers in this assay, from the lowest: compounds 4 and 3 (each within the scatter of the next); then compound 1; then compound 2.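

Unlike the earlier steps, which replace the whole substituent on the shared core, this one keeps the 2-phenylethenyl group and places chloro on an aromatic carbon of its six-membered ring, para to a large group; in this assay this gives a 1.5-fold lower number from compound 3 to compound 4 (0.16 log units; within the scatter), so the ring position takes a chlorine atom with no change that can be told from the scatter. The lead of the 2-phenylethenyl type of substituent over the two substituents with a saturated chain carbon also holds with chloro in place, as a 15-fold lower number from compound 2 to compound 4 (1.19 log units; beyond the scatter) and a 6.8-fold lower number from compound 1 to compound 4 (0.83 log units; beyond the scatter) both stand beyond the scatter and run the same way as the steps to compound 3. No available evidence accounts for these numbers.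

What the compounds shown leave open is whether this ring position accepts groups other than chloro, such as a methoxy group, an amine or a carboxylic acid, and whether chloro behaves the same way on the other carbons of the ring. Also open, on these data alone, is how a longer chain between the shared core and the ring would read in this assay.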